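The source may report more compounds than this note shows. Statements on the series, on what has been measured and on what is new or still open speak of the compounds shown alone.

Compound 1, `CNc1nc(C)c(C(=O)N/N=C/c2cccc(C(F)(F)F)c2)s1`, in a functional assay on MCF7 cells (Homo sapiens) for inhibition, read by MTT assay, with a stated time of 72 h (a higher number here means a weaker inhibitor, a lower number a stronger inhibitor), gives > 100 ug/mL; this value is a limit of the assay and not a number.
Compound 2, `CNc1nc(C)c(C(=O)N/N=C/c2cc(C(F)(F)F)cc(C(F)(F)F)c2)s1`, in this assay gives > 100 ug/mL; this value is likewise a limit of the assay and not a number.
Within the data shown here, compound 3, `CN(C(=O)NC(=O)c1ccc(C(F)(F)F)cc1)c1nc(C(F)(F)F)c(C(=O)N/N=C/c2cccc(C(F)(F)F)c2)s1`, in this assay gives 8.95 ug/mL, the only number among the three measured values.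

From compound 1 to compound 2 the change is trifluoromethyl in place of hydrogen on an aromatic carbon. The step this made in this assay, a step that the two limits leave unreadable from compound 1 to compound 2, cannot be read, since both values sit at the limit of > 100 ug/mL in this assay, at which 2 of the 3 values shown sit. Among the measured compounds shown here, compound 3 stands apart from that pair: the difference between its core and the core of compound 1 is not broken down here, and its value is the one number in the set.

Compound 4, `CN(C(=O)NC(=O)c1ccc(C(F)(F)F)cc1)c1nc(C(F)(F)F)c(C(=O)N/N=C/c2cc(C(F)(F)F)cc(C(F)(F)F)c2)s1`, has not yet been measured. From compound 3 to compound 4 the change is trifluoromethyl in place of hydrogen on an aromatic carbon. The place given for this change matches word for word the place given for the change from compound 1 to compound 2, so it is the same change on a different core. That earlier step gives no size to lean on, so the expectation for compound 4 rests on compound 3 alone, which gave 8.95 ug/mL. Compound 4 is therefore expected to stay close to that value, with an estimated step of a 1.0-fold higher number from compound 3 to compound 4 (0.00 log units; within the scatter) in this assay. The estimated value for compound 4 is 9 ug/mL, expected to fall between 4 ug/mL and 25 ug/mL.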

Compound 4, half-maximal inhibitory concentration: 7.37 ug/mL
Compound 4: the middle estimate sits 1.2-fold (0.09 log units) above what was measured; the measured number falls inside the stated range.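

On the core of compound 3, adding a trifluoromethyl group to the aromatic carbon gives a 1.2-fold lower number from compound 3 to compound 4 (0.08 log units; within the scatter) in this assay, so the two values on this core stand within the usual scatter of each other and the added group shows no readable effect there. The same change on the core of compound 1 gives no size to set against this, since the values of compound 1 and compound 2 are each a limit of the assay and not a number: the limit of > 100 ug/mL in this assay, at which 2 of the 4 values shown sit. The series therefore shows one readable step on one core, and it cannot show whether the change behaves alike on both cores, nor can it show that the absence of a readable effect would hold on any further core.

The compounds shown leave open whether a different group on that same aromatic carbon, such as an amine, a carboxylic acid or a nitrile, would give a step beyond the scatter on the core of compound 3. They also leave open which of the parts that separate the core of compound 3 from the core of compound 1 accounts for the numbers read on the former.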